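The compounds below may be only part of what the source reports. "The series", "measured", "known", "first", "only" and "open" are said of these compounds alone.

Measured so far in a functional assay on L1210 cells (Mus musculus) for cytotoxicity, with a stated time of 48 h; on this read-out lower numbers stand for stronger inhibition and higher numbers for weaker inhibition:
compound 1 `O=C1/C(=C/c2ccc(F)cc2)CCC/C1=C\c1ccc([N+](=O)[O-])cc1`, 26800 nM
compound 2 `O=C1/C(=C/c2ccccc2)CCC/C1=C\c1ccc([N+](=O)[O-])cc1`, 9800 nM

Compound 2 stands at the lowest of the two numbers in this assay; its nearest neighbour is compound 1, separated by the one step shown, a 2.7-fold lower number from compound 1 to compound 2 (0.44 log units; beyond the scatter), which is hydrogen in place of fluoro on an aromatic carbon. That is the whole of what the measured pair says.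

Compound 3 `COc1ccc(/C=C2\CCC/C(=C\c3ccc([N+](=O)[O-])cc3)C2=O)cc1` differs from compound 2 by methoxy in place of hydrogen on an aromatic carbon, para to a large group. For the measured compounds named here, the one measured step concerns the same aromatic carbon and was modest; it shows that a change at this position moves the number beyond the scatter but only by a small margin. Going by the values given here, no measured step covers methoxy itself, so its direction here is open. The expected step in this assay from compound 2 to compound 3 is therefore estimated at a 1.1-fold lower number from compound 2 to compound 3 (0.04 log units; within the scatter), in effect no clear movement beyond the scatter. For compound 3 the estimate in this assay is 9000 nM, within a range of 3000 nM to 30000 nM.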

Compound 3, half-maximal inhibitory concentration: 240000 nM
Compound 3: middle estimate off by 27-fold (1.43 log units), on the low side; the measured number lies above the stated range.
By their numbers in this assay, from the lowest: compound 2; then compound 1; then compound 3.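

In this assay, for the compounds shown here, the change from phenyl to 4-methoxyphenyl gives the largest step so far: a 24-fold higher number from compound 2 to compound 3 (1.39 log units; beyond the scatter). This position therefore tolerates substitution far less evenly than the fluoro pair suggested, since that comparison gave only a modest step, a 2.7-fold lower number from compound 1 to compound 2 (0.44 log units; beyond the scatter), and swapping fluoro for methoxy on the same aromatic carbon still gives a 9.0-fold higher number from compound 1 to compound 3 (0.95 log units; beyond the scatter). Across these three compounds the unsubstituted phenyl carries the lowest number, with both substituents moving the number upward, fluoro by a modest margin and methoxy by a large one, and no compound shown goes against this; nothing at hand accounts for the size of the methoxy step.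

Still open, on these data alone, is where a methyl, a hydroxyl or a dimethylamino group on this same aromatic carbon would fall relative to fluoro and methoxy, and so whether the rise tracks the particular group or any replacement of hydrogen. As far as these compounds go, all three compounds also keep the nitro group on the other aromatic ring, so whether the methoxy step survives with a nitrile or a plain hydrogen there remains unknown.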